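The source may report more compounds than this note shows. Statements on the series, on what has been measured and on what is new or still open speak of the compounds shown alone.

Compound 1, `CC(C)c1c(C(=O)NCC2CCCCC2)nn(-c2ccc(F)cc2)c1OC[C@@H](O)C[C@@H](O)CC(=O)O`, gives 17 nM in an assay on microsomes from liver for inhibition of 3-hydroxy-3-methylglutaryl-coenzyme A reductase (Rattus norvegicus); on this read-out lower numbers stand for stronger inhibition and higher numbers for weaker inhibition.
Compound 2, `CC(C)c1c(C(=O)NCc2cccc(F)c2F)nn(-c2ccc(F)cc2)c1OC[C@@H](O)C[C@@H](O)CC(=O)O`, gives 2 nM in this assay.
Compound 3, `COc1ccc(CNC(=O)c2nn(-c3ccc(F)cc3)c(OC[C@@H](O)C[C@@H](O)CC(=O)O)c2C(C)C)cc1`, gives 12 nM in this assay.

Compound 3 sits second highest of the three numbers. Its nearest neighbour is compound 1, and the step of a 1.4-fold lower number from compound 1 to compound 3 (0.15 log units; within the scatter) lies within the scatter, so the two cannot be ordered. Its furthest is compound 2, and the step of a 6.0-fold higher number from compound 2 to compound 3 (0.78 log units; beyond the scatter) is a modest one beyond the scatter.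

Compound 4, `CC(C)c1c(C(=O)NCc2ccc(Cl)cc2)nn(-c2ccc(F)cc2)c1OC[C@@H](O)C[C@@H](O)CC(=O)O`, differs from compound 3 by chloro in place of methoxy on an aromatic carbon. The measured steps that bear on it are those that swap the group on the saturated chain carbon bound to the amide-type nitrogen: an 8.5-fold lower number from compound 1 to compound 2 (0.93 log units; beyond the scatter) and a 6.0-fold higher number from compound 2 to compound 3 (0.78 log units; beyond the scatter). Both show that a halogenated aryl group in that place gives a lower number than either cyclohexyl or 4-methoxyphenyl. For the measured compounds named here, no measured step changes a single substituent on an otherwise fixed aryl ring, so the size of the step from a methoxy to a chloro remains uncertain. On this evidence compound 4 is expected to give 6 nM, within 2 nM to 18 nM in this assay. That estimate means a step of a 2.0-fold lower number from compound 3 to compound 4 (0.30 log units; within the scatter), expected to lie at the edge of the scatter, towards a lower number.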

Compound 4, half-maximal inhibitory concentration: 6.7 nM
Compound 4: the middle estimate sits 1.1-fold (0.05 log units) below what was measured; measured number inside the range.
By their numbers in this assay, from the lowest: compound 2; then compounds 4, 3 and 1 (each within the scatter of the next, the first and the last beyond it).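

For the compounds shown here, the step of a 1.8-fold lower number from compound 3 to compound 4 (0.25 log units; within the scatter) is the first to change a single substituent on an otherwise fixed aryl ring, and with chloro in place of methoxy, para to a large group, it stays within the scatter in this assay, so compound 3 and compound 4 cannot be ordered. The 4-chlorophenyl group nevertheless separates from cyclohexyl, as the modest step of a 2.5-fold lower number from compound 1 to compound 4 (0.40 log units; beyond the scatter) shows, which 4-methoxyphenyl did not do, yet it also falls short of 2,3-difluorophenyl, as a 3.4-fold higher number from compound 2 to compound 4 (0.53 log units; beyond the scatter) shows, so the two halogenated aryl groups do not give the same result. Nothing available offers an independent measurement that would explain these steps.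

From the compounds shown here alone, what a 4-fluorophenyl or 2,3-dichlorophenyl group would give on the same chain carbon remains open, and with it whether the gap between the two halogenated aryl groups follows the kind of halogen, the number of halogens or their place on the ring. Also open, going by these compounds, is how an amine or a carboxylic acid would compare with chloro and methoxy on that same aromatic carbon.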